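Fluorine on the Pendant Phenyl of Two Isoxazole Cores

The compounds below may be only part of what the source reports. "The series", "measured", "known", "first", "only" and "open" are said of these compounds alone.

The set rests on two cores. Compound 1 `C(=N/c1ccccc1)\c1cc(-c2ccccc2)no1` carries a phenyl on one side of its core and an imine-linked phenyl on the other. In a functional assay on MDA-MB-231 cells (Homo sapiens) for inhibition, read by MTT assay, with a stated time of 24 h (a lower number here means a stronger inhibitor, a higher number a weaker inhibitor), compound 1 gives > 100000 nM, which is a limit of the assay and not a number. Compound 2 `Fc1ccc(-c2cc(/C=N/c3ccccc3)on2)cc1` differs from compound 1 by fluoro in place of hydrogen on an aromatic carbon. In this assay compound 2 gives 41200 nM. As far as these compounds go, the step is an at least 2.4-fold lower number from compound 1 to compound 2 (0.38 log units; beyond the scatter); the direction is a lower number, though its full size is unknown because it starts from a limit (the limit of > 100000 nM in this assay, at which 2 of the 3 values shown sit).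

The second core is that of compound 3 `CCc1cc2ccccc2nc1-c1cc(-c2ccccc2)no1`, in which an ethyl-bearing quinoline replaces the imine-linked phenyl. The difference between the two cores is not broken down here. In this assay compound 3 gives > 100000 nM, which is again a limit of the assay and not a number.

Compound 4 `CCc1cc2ccccc2nc1-c1cc(-c2ccc(F)cc2)no1` has not been measured. It differs from compound 3 by fluoro in place of hydrogen on an aromatic carbon, the same change as that from compound 1 to compound 2, at the same place. Carrying that change over, compound 3 to compound 4 is expected to give an at least 2.0-fold lower number from compound 3 to compound 4 (0.30 log units; that floor lies within the scatter) in this assay, a step of the size seen once before. Because two of the three values sit at a limit (the limit of > 100000 nM in this assay, at which 2 of the 3 values shown sit), there is a real chance that compound 4 also returns only a limit. With that caution, compound 4 is estimated at 50000 nM, in a range from 20000 nM to 150000 nM.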

Compound 4, half-maximal inhibitory concentration: > 100000 nM
Compound 4: no number, only a limit (the forecaster's own chance of this, stated with the estimate: 45%); at least 2.0-fold (0.30 log units) between middle value and limit.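

In this assay compound 4 gives > 100000 nM, which is a limit of the assay and not a number. Compound 3 also stands at a limit, so no step can be read between compound 3 and compound 4. The compounds shown leave open whether phenyl to 4-fluorophenyl lowers the number at all on the core of compound 3, and most values offer no exact figure: the limit of > 100000 nM in this assay, at which 3 of the 4 values shown sit.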